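An Amide Nitrogen Gains a 2-Hydroxyethyl Group

The compounds below may be only part of what the source reports. "The series", "measured", "known", "first", "only" and "open" are said of these compounds alone.

In a functional assay on the whole organism with Mus musculus as the target (a higher number here means that more compound is needed for the effect, a lower number that less compound is needed), compound 3 `NC(=O)/C=C1\CCc2c(F)cc(F)cc21` gives 69 mg/kg. Compound 1 `CCN(C)C(=O)/C=C1\CCc2c(F)cc(F)cc21` gives 56 mg/kg, and these two values lie within the usual scatter of each other. For compound 2 `NC(=O)/C=C1\CCc2c(F)cccc21`, the assay reports only a limit, > 100 mg/kg.

Compound 4 `O=C(/C=C1\CCc2c(F)cc(F)cc21)NCCO` differs from compound 3 by 2-hydroxyethyl in place of hydrogen on an amide-type nitrogen. The most relevant measured change also sits on the amide: amino in place of ethyl(methyl)amino on a carbonyl carbon gave a 1.2-fold higher number from compound 1 to compound 3 (0.09 log units; within the scatter). This shows that, in this one pair, a substantial change at the amide did not move the number beyond the scatter. Fluoro in place of hydrogen on an aromatic carbon gave an at least 1.4-fold lower number from compound 2 to compound 3 (0.16 log units; that floor lies within the scatter), but that change leaves the amide untouched and says little about the new group. Among the compounds with values here, neither measured step points to a clear direction in this assay, and no measured compound carries the 2-hydroxyethyl group, so the range must stay wide. The expected change is small, an estimated 1.1-fold higher number from compound 3 to compound 4 (0.04 log units; within the scatter), with no shift beyond the scatter anticipated. For compound 4, the expected value is 75 mg/kg, with an estimated range of 35 mg/kg to 160 mg/kg.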

Compound 4, dose for half-maximal effect: 100 mg/kg
Beside the measured number, compound 4's estimate is 1.3-fold (0.12 log units) below it; measured number inside the range.
By their numbers in this assay, from the lowest: compounds 1, 3 and 4 (each within the scatter of the next).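

Placing a 2-hydroxyethyl group on the amide nitrogen gives a 1.4-fold higher number from compound 3 to compound 4 (0.16 log units; within the scatter) in this assay, so this position accepts a substituent carrying a hydroxyl group without a shift beyond the scatter. The earlier compounds shown here showed this only for the change between amino and ethyl(methyl)amino, which contains no oxygen. The step of a 1.8-fold higher number from compound 1 to compound 4 (0.25 log units; within the scatter) adds a direct comparison of the two substituted amides, and with it the three amide forms in compounds 1, 3 and 4 are all within the scatter in each listed pair, with no compound among these three going against that pattern.

It remains open whether a longer chain, an amine or a carboxylic acid in place of the 2-hydroxyethyl group would move the number beyond the scatter, since the three amide forms shown give no step of that size. Also open is how these amide changes would read on the core of compound 2, whose result is a limit and not a number: the limit of > 100 mg/kg in this assay, at which 1 of the 4 values shown sits.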